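The source may report more compounds than this note shows. Statements on the series, on what has been measured and on what is new or still open speak of the compounds shown alone.

Measured compounds, with the read-out in a functional assay on WM 266-4 cells (Homo sapiens) for inhibition, read by MTT assay, with a stated time of 24 h; on this read-out lower numbers stand for stronger inhibition of growth and higher numbers for weaker inhibition of growth:

compound 1 `O=C(C1COc2ccccc2O1)N1N=C(c2ccc(Br)cc2)CC1c1ccccc1F` gives 8030 nM
compound 2 `COc1ccc(C2CC(c3ccc(Br)cc3)=NN2C(=O)C2COc3ccccc3O2)cc1` gives 9010 nM
compound 3 `O=C(C1COc2ccccc2O1)N1N=C(c2ccc(Br)cc2)CC1c1cccc(F)c1` gives 7810 nM

The three numbers in this assay lie close together. Compound 1 sits among them with compound 3 as its nearest neighbour, the step being a 1.0-fold lower number from compound 1 to compound 3 (0.01 log units; within the scatter), and compound 2 as its furthest, the step being a 1.1-fold higher number from compound 1 to compound 2 (0.05 log units; within the scatter). The remaining pair, a 1.2-fold lower number from compound 2 to compound 3 (0.06 log units; within the scatter), is of the same kind. None of the three exchanges of the aryl on the saturated ring carbon moved the read-out beyond the scatter.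

Compound 4 `O=C(c1ccc2c(c1)OCCO2)N1N=C(c2ccc(Br)cc2)CC1c1ccccc1F` differs from compound 1 at another place: 2,3-dihydro-1,4-benzodioxin-6-yl in place of 2,3-dihydro-1,4-benzodioxin-2-yl on a carbonyl carbon. Among the measured compounds shown here, no measured step touches the group on the carbonyl carbon, so the three steps bear on this change only indirectly, by showing a series that has so far been flat. They give no direction. For the measured compounds named here, the expected step is therefore a 1.0-fold lower number from compound 1 to compound 4 (0.00 log units; within the scatter), none beyond the scatter, but with a wide range; the change has no precedent among the measured pairs. Compound 4 is estimated at 8000 nM in this assay, with a range from 2500 nM to 25000 nM.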

Compound 4, concentration for 50% growth inhibition: 580 nM
Beside the measured number, compound 4's estimate is 14-fold (1.14 log units) above it; measured number outside the range, below it.
By their numbers in this assay, from the lowest: compound 4; then compounds 3, 1 and 2 (each within the scatter of the next).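

In this assay, among the compounds shown here, the group on the carbonyl carbon is the first place where the read-out moves beyond the scatter: a 14-fold lower number from compound 1 to compound 4 (1.14 log units; beyond the scatter), whereas the three exchanges of the aryl on the saturated ring carbon all stayed within it. The leaving 2,3-dihydro-1,4-benzodioxin-2-yl and the entering 2,3-dihydro-1,4-benzodioxin-6-yl have the same atoms, the same rings and the same counts of donors and acceptors, so compounds 1 and 4 differ only in how this group is joined to the carbonyl carbon, and that difference alone goes with a large step. Nothing measured on these compounds accounts for the step.

Still open is whether the aryl exchanges on the saturated ring carbon remain as flat with 2,3-dihydro-1,4-benzodioxin-6-yl on the carbonyl carbon, as compound 4 is the only compound shown with this group. Also open, from the compounds shown here alone, is what a plain phenyl or a 3,4-dimethoxyphenyl on the carbonyl carbon would give, and so whether the non-aromatic ring of the entering group matters to the step at all.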